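Carbamate side chains at the assay ceiling for cytotoxicity

This account rests on a few compounds, and the source may have more. Where it says the series, first, only, none or still open, it means among the compounds named here.

Compound 1, `CC(C)C[C@H](NC(=O)OCc1cccc(F)c1)C(=O)N[C@H](C=O)C[C@@H]1CCNC1=O`, reaches only the limit > 200000 nM in an ADME assay on Vero C1008 cells (Chlorocebus sabaeus) for cytotoxicity, read by luminescence and CellTiter-Glo, with a stated time of 24 h; on this read-out higher numbers stand for lower toxicity in this test and lower numbers for higher toxicity in this test.
Compound 2, `CC(C)C[C@H](NC(=O)OCCc1cccc(Cl)c1)C(=O)N[C@H](C=O)C[C@@H]1CCNC1=O`, likewise reaches only the limit > 200000 nM in this assay.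
Compound 3, `COc1cccc2[nH]c(C(=O)N[C@@H](CC(C)C)C(=O)N[C@H](C=O)C[C@@H]3CCNC3=O)cc12`, also reaches only the limit > 200000 nM in this assay.

Compound 2 thus stands at the ceiling of this assay, as do both other measured compounds; the limit of > 200000 nM in this assay, at which 3 of the 3 values shown sit, sums this up. The step that the two limits leave unreadable from compound 1 to compound 2 cannot be read, since both ends are limits. Compound 4, `CC(C)C[C@H](NC(=O)O[C@@H](C)c1ccccc1)C(=O)N[C@H](C=O)C[C@@H]1CCNC1=O`, differs from compound 2 by 1-phenylethyl in place of 2-(3-chlorophenyl)ethyl on an oxygen next to a carbonyl group. Going by the values given here, no measured step bears readably on this change, so the only guide is that every compound so far sits at the limit. Compound 4 is therefore expected to remain there as well, with a step that the limit leaves unreadable from compound 2 to compound 4 expected to be no readable step. The estimate for compound 4 is 250000 nM, within 100000 nM to 600000 nM.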

Compound 4, half-maximal cytotoxic concentration: > 200000 nM
Compound 4: no number, only a limit; the forecaster's own chance of this, stated with the estimate: 80%; the middle value does not contradict the limit.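

Compound 4 yields only a limit in this assay, as do compound 1 and compound 2, so neither step to compound 4 can be read. The compounds shown leave open how these side chains differ in cytotoxicity, since all share one ceiling: the limit of > 200000 nM in this assay, at which 4 of the 4 values shown sit.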